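The source may report more compounds than this note shows. Statements on the series, on what has been measured and on what is new or still open speak of the compounds shown alone.

Working notes on the series around compound 2 `CCCSc1nc(NC2CCCCC2)c2ncn([C@@H]3O[C@H](CO)[C@@H](O)[C@H]3O)c2n1`, read in a functional assay on a cell-free system (Platelet, plasma, Homo sapiens) for inhibition, with stated times of 1 min and 3 min; on this read-out lower numbers stand for stronger inhibition and higher numbers for weaker inhibition. Compound 2 gives 151000 nM and compound 3 `CCCCCCNc1nc(SCCC)nc2c1ncn2[C@@H]1O[C@H](CO)[C@@H](O)[C@H]1O` gives 102000 nM. For the measured compounds named here, these are the only two numbers so far and they lie within the scatter of each other, so compound 2 stands level with its one neighbour. Compound 1 `CCCCCCNc1nc(SCC)nc2c1ncn2[C@@H]1O[C@H](CO)[C@@H](O)[C@H]1O` has the entry "not determined" (no result reported), which offers nothing to compare.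

Next in line is compound 4 `CCSc1nc(NC2CCCCC2)c2ncn([C@@H]3O[C@H](CO)[C@@H](O)[C@H]3O)c2n1`, which carries ethylsulfanyl where compound 2 carries propylsulfanyl: hydrogen in place of methyl on a saturated chain carbon, two bonds along the chain from a sulfur.

Going by the values given here, no measured step covers this change. Among the compounds with values here, the only measured step, a 1.5-fold lower number from compound 2 to compound 3 (0.17 log units; within the scatter), places hexyl in place of cyclohexyl on a nitrogen and leaves the propylsulfanyl chain untouched, so it bears on the change only indirectly. It shows a change elsewhere in the molecule staying within the scatter. With no evidence on the chain itself, no step beyond the scatter is expected, and neither direction is favoured. The expected step is a 1.1-fold lower number from compound 2 to compound 4 (0.03 log units; within the scatter), which is an estimate only. For compound 4 the estimated value is 140000 nM, with an expected range of 60000 nM to 300000 nM.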

Compound 4, half-maximal inhibitory concentration: 104000 nM
Estimate against measurement, compound 4: 1.3-fold (0.13 log units) above; the range from low to high includes it.
By their numbers in this assay, from the lowest: compounds 3, 4 and 2 (each within the scatter of the next).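

In this assay the chain on the sulfur now has a measured step of its own, and it reads a 1.5-fold lower number from compound 2 to compound 4 (0.16 log units; within the scatter) for hydrogen in place of methyl on a saturated chain carbon, two bonds along the chain from a sulfur. With cyclohexyl on the nitrogen kept, propylsulfanyl and ethylsulfanyl therefore cannot be told apart on this read-out, just as the change on the nitrogen gave a 1.5-fold lower number from compound 2 to compound 3 (0.17 log units; within the scatter) and left its pair within the scatter, so neither of these two single changes has yet moved the number beyond it. Nothing at hand offers an explanation for this result.

On these data alone, the same change from propylsulfanyl to ethylsulfanyl with hexyl on the nitrogen, from compound 3 to compound 1, cannot be read, as compound 1 has no result reported, so it remains open whether the outcome holds with that group on the nitrogen. Also open, as far as these compounds go, is whether a longer chain such as hexylsulfanyl, or a carboxylic acid at the end of the chain on the sulfur, would give a step beyond the scatter.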